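Carbamate to pyridylmethyl carbamate: permeability of compound 4

This account rests on a few compounds, and the source may have more. Where it says the series, first, only, none or still open, it means among the compounds named here.

Measured so far in an ADME assay on Caco-2 cells (Homo sapiens) for permeability, in the apical to basolateral direction, with a stated time of 90 min, tested at 10 uM; a lower number here means that the compound crosses the layer more slowly, a higher number that the compound crosses the layer faster:
- compound 1 `O=C(NC[C@@H]1[C@H]2CN(C(=O)OCc3cc(Cl)cc(Cl)c3)C[C@@H]12)c1ccc2[nH]c(=O)oc2c1`: 137 10^-6 cm/s
- compound 2 `O=C(NC[C@@H]1[C@H]2CN(C(=O)NCc3cc(Cl)cc(Cl)c3)C[C@@H]12)c1ccc2[nH]c(=O)oc2c1`: 2 10^-6 cm/s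
- compound 3 `CC(OC(=O)N1C[C@@H]2[C@@H](CNC(=O)c3ccc4[nH]c(=O)oc4c3)[C@@H]2C1)c1cc(Cl)cc(Cl)c1`: 118 10^-6 cm/s

Compound 3 sits second highest of the three numbers; its nearest neighbour is compound 1, with a 1.2-fold lower number from compound 1 to compound 3 (0.06 log units; within the scatter), and its furthest is compound 2, with a 59-fold higher number from compound 2 to compound 3 (1.77 log units; beyond the scatter).

Compound 4 `Cc1ccc(COC(=O)N2C[C@@H]3[C@@H](CNC(=O)c4ccc5[nH]c(=O)oc5c4)[C@@H]3C2)nc1` is the next step from compound 3. The change is a group of 8 heavy atoms (7 carbon, 1 nitrogen; one six-membered aromatic ring with 1 hetero atom) in place of a group of 10 heavy atoms (8 carbon, 2 chlorine; one six-membered aromatic ring of carbon only), on an oxygen next to a carbonyl group.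

Within the data shown here, none of the measured steps covers this exact change. The one large effect in this assay, a 69-fold lower number from compound 1 to compound 2 (1.84 log units; beyond the scatter), concerns the carbonyl-bound atom, which compound 4 keeps as in compound 3 and compound 1. The step of a 1.2-fold lower number from compound 1 to compound 3 (0.06 log units; within the scatter) shows that altering the group on the oxygen next to the carbonyl need not move the number. Swapping the aryl ring for one with a hetero atom is untested here, so a move beyond the scatter cannot be excluded, but the two carbamates both read high.

Compound 4 is therefore expected to stay in the upper range, with an estimate of 70 10^-6 cm/s (range 25 10^-6 cm/s to 150 10^-6 cm/s), a step of a 1.7-fold lower number from compound 3 to compound 4 (0.23 log units; within the scatter) being expected and likely within or only modestly beyond the scatter.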

Compound 4, apparent permeability in the Caco-2 assay: 1 10^-6 cm/s
The estimate for compound 4 lay 70-fold (1.85 log units) above the measured number, outside the stated range (below it).
By their numbers in the Caco-2 assay, from the lowest: compounds 4 and 2 (each within the scatter of the next); then compounds 3 and 1 (each within the scatter of the next).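

In the Caco-2 assay, the group on an oxygen next to a carbonyl group proves far from silent, although the earlier carbamates suggested otherwise: (5-methylpyridin-2-yl)methyl gives a 120-fold lower number from compound 3 to compound 4 (2.07 log units; beyond the scatter), and 5-methylpyridin-2-yl in place of 3,5-dichlorophenyl gives a 140-fold lower number from compound 1 to compound 4 (2.14 log units; beyond the scatter). A carbamate is therefore no guarantee of a high number in this series, and the step of a 2.0-fold lower number from compound 2 to compound 4 (0.30 log units; within the scatter) places compound 4 level with the urea-type compound 2, so a low reading is reached through either of two different changes. In a physicochemical assay for solubility, with a stated time of 24 h, at pH 4.5 (a lower number here means a less soluble compound, a higher number a more soluble compound), the same change runs the opposite way, an at least 66-fold higher number from compound 3 to compound 4 (1.81 log units; beyond the scatter). In the physicochemical assay compound 3 gives < 1 ug/mL, and this reading is a limit of the assay and not a number: the limit of < 1 ug/mL in the physicochemical assay, at which 1 of the 2 values shown sits. In the physicochemical assay compound 4 gives 66 ug/mL.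

Open is whether the step follows the ring nitrogen, the methyl or the loss of the chlorine atoms, as the compounds shown change these together. A phenyl or a 5-chloropyridin-2-yl on a saturated chain carbon bound to an oxygen next to a carbonyl group would help to separate them, and would test whether a high number in the Caco-2 assay and a high number in the physicochemical assay can sit in one compound.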